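This account rests on a few compounds, and the source may have more. Where it says the series, first, only, none or still open, it means among the compounds named here.

Three compounds from one series carry the same core and have been measured in an assay on CHO cells for displacement of a labelled ligand from 5-hydroxytryptamine receptor 1B (Homo sapiens); a lower number here means a stronger inhibitor, a higher number a weaker inhibitor. Compound 1 `COC[C@H](NC1CCN(CCCc2c[nH]c3ccc(Cn4cncn4)cc23)CC1)c1ccc(F)cc1` gives 1200 nM there. Compound 2 `c1ccc(C2CCCCN2C2CCN(CCCc3c[nH]c4ccc(-n5cnnc5)cc34)CC2)cc1` gives 410 nM in this assay. Compound 3 `CC(C)=CCCN(C)C1CCN(CCCc2c[nH]c3ccc(-n4cnnc4)cc23)CC1` gives 24 nM in this assay, the lowest of the three numbers; its gaps to compound 2 and to compound 1 are both beyond the scatter, so among these three compound 3 is the strongest inhibitor.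

Compound 4 `CN(C1CCN(CCCc2c[nH]c3ccc(-n4cnnc4)cc23)CC1)S(=O)(=O)c1ccccc1` has not yet been measured. It differs from compound 3 in one place: phenylsulfonyl in place of 4-methylpent-3-en-1-yl on an amine nitrogen. Put another way, methyl(4-methylpent-3-en-1-yl)amino becomes methyl(phenylsulfonyl)amino, on an amine nitrogen whose other neighbours are a saturated chain carbon and a saturated ring carbon.

Going by the values given here, no single-change step between measured compounds is available to anchor this change. What the set does show is that compound 1, carrying an aromatic ring on the group at this end of the molecule, gave 1200 nM, and compound 2, which also carries an aromatic ring there, gave 410 nM, both well above compound 3. On that basis compound 4 is expected to come in weaker than compound 3, with a step of a 6.3-fold higher number from compound 3 to compound 4 (0.80 log units; beyond the scatter) that is estimated to lie beyond the scatter. For compound 4 the expected value in this assay is 150 nM, in an estimated range from 40 nM to 600 nM.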

Compound 4, half-maximal inhibitory concentration: 10 nM
For compound 4 the middle estimate is 15-fold (1.18 log units) above the measured one, and the stated range ends above it.
By their numbers in this assay, from the lowest: compound 4; then compound 3; then compound 2; then compound 1.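

Going by these compounds alone, the single change on this amine nitrogen, with its neighbouring saturated chain carbon and saturated ring carbon, gives a 2.4-fold lower number from compound 3 to compound 4 (0.38 log units; beyond the scatter) in this assay, a modest step and the first direct reading of a change at this position. It shows that an aromatic ring at this end of the molecule does not by itself bring a weaker number: compound 4 carries phenylsulfonyl, with its six-membered aromatic ring, and still stands below compound 3, so the aromatic groups of compound 1 and compound 2 cannot be read as a penalty on their own. Nothing shown gives a measured reason for this step.

The compounds shown leave open whether the step belongs to the sulfonyl link or to the phenyl ring, a question that a benzoyl or benzyl group on the same nitrogen, or a methanesulfonyl group, would help to separate. They also leave open how far the number moves with a fluorine or methoxy group on that phenyl ring, or with a pyridine ring in its place.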